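Moving a methyl on the tolyl ring of a triazole sulfonamide series

This account rests on a few compounds, and the source may have more. Where it says the series, first, only, none or still open, it means among the compounds named here.

Compound 1 `Cc1cccc(-n2cc(-c3ccccc3NS(=O)(=O)c3c[nH]c(=O)[nH]c3=O)nn2)c1` is the reference point of this small set. In a functional assay on HepG2 cells (Homo sapiens) for antiproliferative activity, read by MTT assay, with a stated time of 24 h (a higher number here means a weaker inhibitor, a lower number a stronger inhibitor), compound 1 gives 3620 nM. Compound 2 `Cc1ccc(-n2cc(-c3ccccc3NS(=O)(=O)c3c[nH]c(=O)[nH]c3=O)nn2)cc1` differs from it by one change, (4-methylphenyl in place of 3-methylphenyl on an aromatic nitrogen), and in this assay compound 2 gives 8350 nM; the step of a 2.3-fold higher number from compound 1 to compound 2 (0.36 log units; beyond the scatter) is therefore a modest loss that lies beyond the scatter. Compound 3 `Cc1cccc(-n2cc(-c3cccc(NS(=O)(=O)c4c[nH]c(=O)[nH]c4=O)c3)nn2)c1` carries the sulfonamide on a different position of the central benzene, and the difference between its core and that of compound 1 is not broken down here. In this assay compound 3 gives 7050 nM, which sits within the scatter of both compound 1 and compound 2, so no ranking among the three is justified.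

Compound 4 `Cc1ccc(-n2cc(-c3cccc(NS(=O)(=O)c4c[nH]c(=O)[nH]c4=O)c3)nn2)cc1` has not been measured. It is made from compound 3 by 4-methylphenyl in place of 3-methylphenyl on an aromatic nitrogen, and the surroundings of the change are the same as in the move from compound 1 to compound 2, so this is the same change. Because a 2.3-fold higher number from compound 1 to compound 2 (0.36 log units; beyond the scatter) weakened the inhibitor, compound 4 is expected to show a step of a 2.0-fold higher number from compound 3 to compound 4 (0.30 log units; within the scatter) in this assay. Compound 4 is therefore estimated at 14000 nM, with a range from 6500 nM to 32000 nM.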

Compound 4, half-maximal inhibitory concentration: > 20000 nM
Compound 4 gave a limit, no number (the forecaster's own chance of this, stated with the estimate: 15%); at least 1.4-fold (0.15 log units) between middle value and limit.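

In this assay compound 4 gives > 20000 nM, which is a limit of the assay and not a number. Placing 4-methylphenyl in place of 3-methylphenyl on the aromatic nitrogen gives an at least 2.8-fold higher number from compound 3 to compound 4 (0.45 log units; beyond the scatter), and the same change on the other core gives a 2.3-fold higher number from compound 1 to compound 2 (0.36 log units; beyond the scatter), so on both cores shown the change weakens the inhibitor by a step beyond the scatter. This shows that the direction of the change carried over between these two cores, but it does not show that its size carried over, and two cores alone establish no rule for the series: the same change on two cores in this assay, a 2.3-fold higher number (0.36 log units; beyond the scatter) from compound 1 to compound 2 and an at least 2.8-fold higher number (0.45 log units; beyond the scatter) from compound 3 to compound 4; the limit leaves it open whether they differ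

The compounds shown leave open how a phenyl ring without the methyl, or one bearing a chlorine, a methoxy group, an amine or a carboxylic acid in place of the methyl, would behave in this assay. They also leave open whether a longer chain such as ethyl or propyl at either position named here would follow the same direction on both cores.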